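Amino in Place of Chloro on a Shared Core

A few compounds are considered here, and "the series" means these few. Any claim that something is new, unique, unknown or untested is made for them only; others in the source may bear on it.

Compound 1 `ClCc1ccccc1Cn1cnc2c(Cl)nc(Cl)nc21`: 9550 nM
Compound 2 `ClCc1cccc(Cn2cnc3ncnc(Cl)c32)c1`: 6600 nM
Compound 3 `ClCc1cccc(Cn2cnc3c(Cl)nc(Cl)nc32)c1`: 27500 nM

Of the compounds shown here, three have been tested in a functional assay on A498 cells (Homo sapiens) for cytotoxicity, read by sulforhodamine B assay, with a stated time of 48 h; a higher number here means that more compound is tolerated, a lower number that less compound is tolerated. Compound 1 gives 9550 nM, the second highest of the three numbers. Its nearest neighbour is compound 2 with 6600 nM, a number that sits within the usual scatter of repeated measurements, so the two cannot be told apart. Compound 3 with 27500 nM lies furthest from compound 1, and that gap is beyond the scatter, so compound 3 is tolerated in clearly larger amounts than compound 1.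

Compound 4 `Nc1nc(Cl)c2ncn(Cc3ccccc3CCl)c2n1` is the next compound to be measured in this assay. It differs from compound 1 in one place: amino in place of chloro on an aromatic carbon. Among the compounds with values here, no measured pair in this set shows the effect of exchanging chloro for amino, so the expected size of the step rests on the structural change alone. The exchange is expected to give at most a modest shift, toward a lower number if any, so the step from compound 1 to compound 4 is estimated as a 1.4-fold lower number from compound 1 to compound 4 (0.13 log units; within the scatter). For compound 4 the expected value in this assay is 7000 nM, with a range from 2500 nM to 20000 nM.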

Compound 4, concentration lethal to 50% of the cells: 95500 nM
Compound 4: middle estimate off by 14-fold (1.13 log units), on the low side; the whole stated range lies below it.
By their numbers in this assay, from the lowest: compounds 2 and 1 (each within the scatter of the next); then compound 3; then compound 4.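

In this assay, amino in place of chloro on the aromatic carbon between two ring nitrogen atoms gives a 10-fold higher number from compound 1 to compound 4 (1.00 log units; beyond the scatter) and so lies beyond the scatter. Within the data shown here, this is the first step in the set between two compounds that differ in one place, and it shows that far more compound is tolerated once this chloro group gives way to amino. Nothing measured in this set explains why the step is this large.

The compounds shown leave open whether this step is specific to amino or whether methylamino, dimethylamino or methoxy at the same carbon would give a similar number. They also leave open whether the same exchange on compound 3, which carries its chloromethyl group elsewhere on the benzene ring, would give a step of similar size.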